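Swapping methoxy for bromo on compound 3

The source may report more compounds than this note shows. Statements on the series, on what has been measured and on what is new or still open speak of the compounds shown alone.

Compound 1 `COc1ccc(NC(=S)Nc2nc(C(=O)NCCCc3ccccc3)cs2)cc1` gives 44800 nM
Compound 2 `CCOC(=O)c1csc2nc(CN3CCN(C)CC3)c(-c3ccc(OC)cc3)n12` gives 44600 nM
Compound 3 `CCOC(=O)c1csc2nc(CN3CCN(Cc4ccccc4)CC3)c(-c3ccc(OC)cc3)n12` gives 19600 nM

In a functional assay on HCT-116 cells (Homo sapiens) for antiproliferative activity, read by MTT assay, with a stated time of 72 h (on this read-out lower numbers stand for stronger inhibition and higher numbers for weaker inhibition), compound 3 has the lowest of these three numbers (19600 nM). Compound 4 `CCOC(=O)c1csc2nc(CN3CCN(Cc4ccccc4)CC3)c(-c3ccc(Br)cc3)n12` differs from it in one place (bromo in place of methoxy on an aromatic carbon): bromo in place of methoxy on an aromatic carbon. Within the data shown here, the only measured step (a 2.3-fold lower number from compound 2 to compound 3 (0.36 log units; beyond the scatter)) lies elsewhere in the molecule, so no measurement tests this position. Among the measured compounds shown here, its modest size is the only guide, and no step beyond the scatter is expected in this assay, in either direction. The expected step is small (a 1.1-fold lower number from compound 3 to compound 4 (0.04 log units; within the scatter)). For compound 4 the estimate is 18000 nM, with an expected range from 6000 nM to 45000 nM.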

Compound 4, half-maximal inhibitory concentration: 37200 nM
Compound 4: the middle estimate sits 2.1-fold (0.32 log units) below what was measured, and the stated range covers the measured number.
By their numbers in this assay, from the lowest: compounds 3, 4, 2 and 1 (each within the scatter of the next, the first and the last beyond it).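

Among these compounds, replacing the 4-methoxyphenyl with the 4-bromophenyl gives a 1.9-fold higher number from compound 3 to compound 4 (0.28 log units; within the scatter) in this assay and so provides the first measurement at this position. Exchanging methoxy, with its one hydrogen-bond acceptor, for bromo, with none, leaves compound 3 and compound 4 indistinguishable on this read-out. No measured evidence bears on this result. Still open, from the compounds shown here alone, is whether a different group on this aromatic carbon, such as an amine, a carboxylic acid or a longer chain, would produce a step beyond the scatter.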